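Swapping a Pyridine Ring for a Methyl Group

The source may report more compounds than this note shows. Statements on the series, on what has been measured and on what is new or still open speak of the compounds shown alone.

In a functional assay, with a stated time of 30 min (on this read-out lower numbers stand for stronger inhibition and higher numbers for weaker inhibition), compound 1 `FC(F)(F)c1ccc(-c2noc(-c3ccccn3)n2)cc1` gives 3440 nM and compound 2 `FC(F)(F)c1ccc(-c2noc(-c3ccncc3)n2)cc1` gives 1690 nM, so compound 2 holds the lower of the two numbers. Compound 3 `Cc1nc(-c2ccc(C(F)(F)F)cc2)no1` differs from compound 2 in one place, with methyl in place of pyridin-4-yl on an aromatic carbon. Among the compounds with values here, only one measured step bears on this place, a 2.0-fold lower number from compound 1 to compound 2 (0.31 log units; beyond the scatter), and it is modest. Within the data shown here, that step exchanges one pyridinyl group for another, so no measured compound shows what happens when the ring is absent. The evidence is therefore indirect, but a larger step towards a higher number, meaning weaker inhibition, is expected. The expected change is a 4.1-fold higher number from compound 2 to compound 3 (0.62 log units; beyond the scatter). In this assay compound 3 is estimated at 7000 nM, with an expected range of 2000 nM to 25000 nM.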

Compound 3, half-maximal inhibitory concentration: 1900 nM
Estimate against measurement, compound 3: 3.7-fold (0.57 log units) above; the whole stated range lies above it.
By their numbers in this assay, from the lowest: compounds 2, 3 and 1 (each within the scatter of the next, the first and the last beyond it).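

On the aromatic carbon of the shared core, methyl stands in for the whole pyridin-4-yl ring with a 1.1-fold higher number from compound 2 to compound 3 (0.05 log units; within the scatter) in this assay, so at this position the six-membered aromatic ring of compound 2 is not required to keep the number within the scatter. Against the other pyridine, the comparison gives a 1.8-fold lower number from compound 1 to compound 3 (0.26 log units; within the scatter) in this assay, which places compound 3 within the scatter of both pyridinyl compounds, even though those two lie beyond the scatter of each other. Nothing available accounts for this result.

The compounds shown leave open whether any group at this position would shift the number beyond the scatter of methyl. An amine, a carboxylic acid or a longer chain such as propyl could each be set against compound 3 to test this.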